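The source may report more compounds than this note shows. Statements on the series, on what has been measured and on what is new or still open speak of the compounds shown alone.

Measured in an assay on isolated protein for displacement of a labelled ligand from metabotropic glutamate receptor 5 (Homo sapiens), with a stated time of 60 min, tested at 1 uM; on this read-out lower numbers stand for less inhibition and higher numbers for more inhibition at the one concentration tested (going by the name of the read-out):

compound 1 `Cc1ccc2ncc(S(=O)(=O)c3ccc(C#N)cc3)c(N3CCC(C)CC3)c2c1` — 55%
compound 2 `COc1ccc2ncc(S(=O)(=O)c3cccc(F)c3)c(N3CCC(C)CC3)c2c1` — 68%
compound 3 `COc1ccc(S(=O)(=O)c2cnc3cc(Cl)ccc3c2N2CCC(C)CC2)cc1OC` — 93%

Compound 1 stands lowest of the three numbers in this assay. Compound 2 gives a number higher than compound 1 by more than the usual scatter, and compound 3 gives a number higher still, again beyond the scatter. Within the data shown here, the three differ from one another in several places at once, so no single-point step between measured compounds can be read off.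

Compound 4 `Cc1cc(C)cc(S(=O)(=O)c2cnc3ccc(C)cc3c2N2CCC(C)CC2)c1` differs from compound 1 in one place: 3,5-dimethylphenyl in place of 4-cyanophenyl on a sulfonyl sulfur. Nothing measured here isolates this change. What the numbers do show is that the two compounds that lack the 4-cyanophenyl group on the sulfonyl sulfur, compound 2 with 68% and compound 3 with 93%, both sit higher than compound 1. On that basis a step upward is expected for compound 4, of moderate size, a number 20 percentage points higher from compound 1 to compound 4 (beyond the scatter), though with wide uncertainty since the entering group matches neither of those. Compound 4 is therefore estimated at 75%, with a range from 50% to 95%.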

Compound 4, a percentage reported as inhibition, at one concentration (the size of the read-out at that concentration, not a potency): 80%
Compound 4: middle estimate off by 5 percentage points, on the low side, within the range that was stated.
By their numbers in this assay, from the lowest: compound 1; then compound 2; then compound 4; then compound 3.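

In this assay, the change from 4-cyanophenyl to 3,5-dimethylphenyl on a sulfonyl sulfur gives a number 25 percentage points higher from compound 1 to compound 4 (beyond the scatter). Among these compounds, this is the first comparison that isolates one place, and it shows that the read-out responds to the aryl group on the sulfonyl sulfur alone, something compounds differing in several places at once could not show. No supporting data bear on why the number rises, so the step stands as an observation only.

The compounds shown do not separate the loss of the nitrile from the gain of the two methyl groups, a question that unsubstituted phenyl on the same sulfonyl sulfur would address. Also open, from the compounds shown here alone, is whether the step carries over to the methoxy and chloro cores of compound 2 and compound 3.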